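The source may report more compounds than this note shows. Statements on the series, on what has been measured and on what is new or still open speak of the compounds shown alone.

Measured so far:
Compound 1 `CCN(CC)c1c(C)n(C)c(=O)n(-c2ccccc2)c1=O`: 2.11
Compound 2 `CCCNc1c(C)n(C)c(=O)n(-c2ccccc2)c1=O`: 1.2
Compound 3 `CCN(CC)c1c(C)n(-c2ccccc2)c(=O)n(C)c1=O`: 2.19

In a physicochemical assay for lipophilicity (on this read-out lower numbers stand for lower lipophilicity and higher numbers for higher lipophilicity), compound 1 gives 2.11 and compound 2 gives 1.2. The change between them is propylamino in place of diethylamino on an aromatic carbon, and it produced a number 0.91 log units lower from compound 1 to compound 2 (beyond the scatter). Compound 3 is built from the same atoms as compound 1, joined differently; the difference between the two cores is not broken down here. In this assay compound 3 gives 2.19, which sits within the scatter of compound 1.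

Compound 4 `CCCNc1c(C)n(-c2ccccc2)c(=O)n(C)c1=O` carries the same change on the core of compound 3: propylamino in place of diethylamino on an aromatic carbon. The surroundings of the exchanged group are described in the same words for both pairs, so this is the same change. The expectation for compound 4 rests on the step of a number 0.91 log units lower from compound 1 to compound 2 (beyond the scatter). In this assay a step of a number 0.91 log units lower from compound 3 to compound 4 (beyond the scatter) is therefore expected. Compound 4 is estimated at 1.28, in a range from 1 to 1.55.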

Compound 4, partition coefficient: 1.7
The estimate for compound 4 lay 0.42 log units below the measured number; the whole stated range lies below it.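

In this assay the exchange of diethylamino for propylamino gave a number 0.49 log units lower from compound 3 to compound 4 (beyond the scatter) where the earlier pair gave a number 0.91 log units lower from compound 1 to compound 2 (beyond the scatter) on the other core, so the direction carried over while the size did not carry in full. Going by these compounds alone, with only two pairs, this shows that the step need not keep its size from one core to the other, but it gives no rule for how the size will shift on any further core. Nothing at hand accounts for the difference between the two steps.

On these data alone, it remains open whether a cyclic amine such as morpholine or a longer chain such as butylamino would follow the same direction on both cores. As far as these compounds go, whether dimethylamino in place of diethylamino would differ between the cores also remains open.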